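Amide hydroxamates in this assay: trimming the amine substituent

The source may report more compounds than this note shows. Statements on the series, on what has been measured and on what is new or still open speak of the compounds shown alone.

Of the compounds shown here, three have been measured in a functional assay on HCT-116 cells (Homo sapiens) for antiproliferative activity, read by MTT assay, with a stated time of 48 h; a lower number here means a stronger inhibitor of growth, a higher number a weaker inhibitor of growth. Compound 1 `CCCCCCN(Cc1ccc(C(=O)NO)cc1)c1ncc(-c2ccc(C)cc2)s1` gives 4850 nM. Compound 2 `Cc1ccc(-c2cnc(N(Cc3ccc(C(=O)NO)cc3)CC(C)C)s2)cc1` gives 5900 nM, and compound 3 `Cc1ccc(-c2cnc(N(CCCOc3ccccc3)Cc3ccc(C(=O)NO)cc3)s2)cc1` gives 4140 nM. Compound 3 has the lowest of the three numbers, but its gap to the others is small: a 1.2-fold lower number from compound 1 to compound 3 (0.07 log units; within the scatter) and a 1.4-fold lower number from compound 2 to compound 3 (0.15 log units; within the scatter), and the remaining pair, a 1.2-fold higher number from compound 1 to compound 2 (0.09 log units; within the scatter), is also within the scatter. Across these three compounds the substituent on the ring nitrogen has not moved the growth inhibition beyond the scatter.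

Compound 4 `Cc1ccc(-c2cnc(N(Cc3ccc(C(=O)NO)cc3)C(C)C)s2)cc1` has not yet been measured. It differs from compound 3 by isopropyl in place of 3-phenoxypropyl on a nitrogen on an aromatic ring. The closest measured step is a 1.4-fold lower number from compound 2 to compound 3 (0.15 log units; within the scatter), which removes a similar phenoxyalkyl chain in favour of a branched alkyl and stays within the scatter; a 1.2-fold higher number from compound 1 to compound 2 (0.09 log units; within the scatter) shows the same indifference to chain shape. The expected step is therefore a 1.3-fold higher number from compound 3 to compound 4 (0.12 log units; within the scatter), with no direction beyond the scatter. Compound 4 is estimated at 5500 nM, with a range from 2500 nM to 12000 nM.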

Compound 4, concentration for 50% growth inhibition: 7800 nM
The estimate for compound 4 lay 1.4-fold (0.15 log units) below the measured number; the range from low to high includes it.
By their numbers in this assay, from the lowest: compounds 3, 1, 2 and 4 (each within the scatter of the next).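

Even the largest change at this nitrogen so far, with 3-phenoxypropyl (10 heavy atoms, one aromatic ring) leaving and isopropyl (3 heavy atoms, no ring) entering, gives a 1.9-fold higher number from compound 3 to compound 4 (0.28 log units; within the scatter) and so stays inside the scatter in this assay. The exchanges from the two plain alkyl chains behave alike, with hexyl giving way to isopropyl in a 1.6-fold higher number from compound 1 to compound 4 (0.21 log units; within the scatter) and isobutyl giving way to isopropyl in a 1.3-fold higher number from compound 2 to compound 4 (0.12 log units; within the scatter) as the reading. On a nitrogen on an aromatic ring, then, neither the aromatic ring and ether oxygen of the side chain nor the alkyl chain forms compared here separate these four compounds, and no measurement at hand speaks to the reason.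

From the compounds shown here alone, whether a side chain ending in an amine or a carboxylic acid would move growth inhibition beyond the scatter remains open. So does the effect of a bare hydrogen on this nitrogen in place of any chain.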